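Aryl swap on a thiosemicarbazone: fluoro to methoxy

The compounds below may be only part of what the source reports. "The series", "measured", "known", "first", "only" and "open" are said of these compounds alone.

Measured so far:
Compound 1 `Fc1cccc(NC(=S)N/N=C/c2ccc3ccccc3n2)c1` — 43800 nM
Compound 2 `CN(C)C(=S)N/N=C/c1cnc2ccccc2n1` — 90 nM
Compound 3 `Cc1csc2sc(/C=N/NC(N)=S)c(C)c12` — the limit of > 100000 nM in this assay, at which 1 of the 3 values shown sits.

The three compounds share a thiosemicarbazone linkage but differ in the group on the amide-type nitrogen and in the aromatic core. In a functional assay on HL-60 cells (Homo sapiens) for antiproliferative activity, read by sulforhodamine B assay, with a stated time of 72 h (a higher number here means a weaker inhibitor, a lower number a stronger inhibitor), compound 1 gives 43800 nM, the highest of the two numbers reported, so it is the weaker inhibitor of that pair. Compound 2 gives 90 nM, a much lower number and a far stronger inhibitor; the gap to compound 1 lies well beyond the scatter. Compound 3 gives > 100000 nM, which is a limit of the assay and not a number.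

Compound 4 `COc1ccc(NC(=S)N/N=C/c2ccc3ccccc3n2)cc1` is not yet measured. It keeps the core of compound 1 and changes only the group on the amide-type nitrogen: 4-methoxyphenyl in place of 3-fluorophenyl on an amide-type nitrogen. Among the compounds with values here, no measured pair here isolates this change, so there is no directly comparable step. For compound 4 a modest shift in this assay is expected, likely within or near the scatter, with the direction uncertain; the expected step of a 1.3-fold lower number from compound 1 to compound 4 (0.10 log units; within the scatter) is small. Compound 4 is estimated at 35000 nM, ranging from 9000 nM to 100000 nM.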

Compound 4, half-maximal inhibitory concentration: 43800 nM
The estimate for compound 4 lay 1.3-fold (0.10 log units) below the measured number; measured number inside the range.
By their numbers in this assay, from the lowest: compound 2; then compounds 1 and 4 (each within the scatter of the next). At a limit, above all of these: compound 3.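

In this assay, within the data shown here, compounds 1 and 4 give the first direct reading of the group on the amide-type nitrogen with the core of compound 1 held fixed, and putting 4-methoxyphenyl in place of 3-fluorophenyl gives no change at the digits printed from compound 1 to compound 4 (within the scatter). This one pair therefore does not separate the two aryl groups in this assay, even though the swap removes fluorine and adds oxygen, along with the hydrogen-bond acceptor counted for 4-methoxyphenyl. Nothing measured among these compounds accounts for the two aryl groups reading alike.

Compound 2 and compound 3 each differ from compound 1 in more than one place, so they cannot show how much of any gap comes from the group on this nitrogen and how much from the core. As far as these compounds go, it remains open whether a different kind of group on this nitrogen, such as a morpholine ring, a longer alkyl chain or an aryl ring carrying a carboxylic acid, would shift the number on the core of compound 1.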